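Two inactive limits and an untested heteroaryl swap

The compounds below may be only part of what the source reports. "The series", "measured", "known", "first", "only" and "open" are said of these compounds alone.

This study asks how changing the aromatic group on the side chain of a shared core affects growth inhibition of cervical cancer cells. In a functional assay on HeLa cells (Homo sapiens) for antiproliferative activity, read by MTT assay, with a stated time of 72 h (on this read-out lower numbers stand for stronger inhibition and higher numbers for weaker inhibition), compound 2 `O=C1O/C(=C\Cn2cnc3c(F)nc(F)c(Cl)c32)C(OCc2ccccc2)=C1OCc1ccccc1` reaches only a limit, > 100000 nM, not a number. Compound 1 `O=C1NC(O)(/C=C\n2cc(I)c3c(Cl)ncnc32)C(OCc2ccccc2)=C1OCc1ccccc1` also gives only a limit in this assay, > 250000 nM. For the measured compounds named here, both results are limits, so no measured step between them can be described, as the limit of > 100000 nM in this assay, at which 1 of the 2 values shown sits, and the limit of > 250000 nM in this assay, at which 1 of the 2 values shown sits, show. Compound 3 `O=C1O/C(=C\Cn2cnc3cc[nH]c3c2=O)C(OCc2ccccc2)=C1OCc1ccccc1` has not yet been tested. It differs from compound 2 by a group of 10 heavy atoms (6 carbon, 3 nitrogen, 1 oxygen; one five-membered aromatic ring with 1 hetero atom, one six-membered aromatic ring with 2 hetero atoms) in place of a group of 12 heavy atoms (6 carbon, 3 nitrogen, 2 fluorine, 1 chlorine; one five-membered aromatic ring with 2 hetero atoms, one six-membered aromatic ring with 1 hetero atom), on a saturated chain carbon bound to a double-bonded chain carbon. Going by the values given here, with no measured step to draw on, no shift beyond the usual scatter can be expected from compound 2 to compound 3, and the step is estimated at a step that the limit leaves unreadable from compound 2 to compound 3. In this assay compound 3 is therefore expected to give about 150000 nM, within 30000 nM to 500000 nM, quite possibly as another limit.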

Compound 3, half-maximal inhibitory concentration: 27000 nM
For compound 3 the middle estimate is 5.6-fold (0.74 log units) above the measured one, outside the stated range (below it).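

At the saturated chain carbon bound to a double-bonded chain carbon, the group carried does change the result: in this assay, replacing the group bearing fluorine and chlorine with the one holding an oxygen and no halogen gives an at least 3.7-fold lower number from compound 2 to compound 3 (0.56 log units; beyond the scatter). For the compounds shown here, compound 3 is the only compound here with a measured number rather than a limit, so activity at this position can now be read at all. The true size of the step stays unknown, since its starting point is only a limit: the limit of > 100000 nM in this assay, at which 1 of the 3 values shown sits.

One change cannot separate the loss of fluorine and chlorine from the added hydrogen-bond donor, as both arrive together. As far as these compounds go, whether a simple amine or a carboxylic acid on this chain would keep or extend the gain also stays open.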